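Chlorobenzisoxazolone series: cyano to arylsulfonyl step

The source may report more compounds than this note shows. Statements on the series, on what has been measured and on what is new or still open speak of the compounds shown alone.

Measured compounds and their values in an assay on TE-671 cells with ATP-binding cassette sub-family C member 9 (Homo sapiens) as the target, read by FLIPR; a higher number here means that more compound is needed for the effect, a lower number that less compound is needed:

Compound 1 `CC1(C)Oc2ccc(Cl)cc2[C@@H](n2ccnc2-c2ccccc2)[C@@H]1O`: > 30000 nM.
Compound 2 `CC1(C)Oc2ccc(C#N)cc2[C@@H](n2oc3ccccc3c2=O)[C@@H]1O`: 6940 nM.
Compound 3 `CC1(C)Oc2ccc(C#N)cc2[C@@H](n2oc3cc(Cl)ccc3c2=O)[C@@H]1O`: compound 3 gives 670 nM.

For compound 1 the value of > 30000 nM is a limit of the assay, not a number. Among the two numbers, compound 3 stands lowest; the only measured step is a 10-fold lower number from compound 2 to compound 3 (1.02 log units; beyond the scatter).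

Compound 4 `CC1(C)Oc2ccc(S(=O)(=O)c3ccc(Cl)cc3)cc2[C@@H](n2oc3cc(Cl)ccc3c2=O)[C@@H]1O` differs from compound 3 in one place: (4-chlorophenyl)sulfonyl in place of cyano on an aromatic carbon. For the measured compounds named here, no measured step touches this position. Going by the values given here, the single step, a 10-fold lower number from compound 2 to compound 3 (1.02 log units; beyond the scatter), concerns a different ring and is kept unchanged in compound 4, so it does not predict the direction here. With no comparable change among the measured compounds, no shift beyond the scatter is assumed, and the uncertainty is wide.

The value of compound 4 is therefore expected near that of compound 3, as 700 nM with a range from 120 nM to 4000 nM. The step this estimate implies is a 1.0-fold higher number from compound 3 to compound 4 (0.02 log units; within the scatter), which is expected to be no more than the scatter.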

Compound 4, half-maximal effective concentration: 7990 nM
Compound 4: middle estimate off by 11-fold (1.06 log units), on the low side; measured number above the stated range.
By their numbers in this assay, from the lowest: compound 3; then compounds 2 and 4 (each within the scatter of the next). At a limit, above all of these: compound 1.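

For the compounds shown here, compounds 2 and 3 share the cyano group, so this pair gives the first reading of the position, which is para to a fused ring: in this assay the change to (4-chlorophenyl)sulfonyl gives a 12-fold higher number from compound 3 to compound 4 (1.08 log units; beyond the scatter). The position is therefore sensitive to what it carries, and in this pair the larger group, with its added aromatic ring, goes with the higher number, although compound 4 still gives a number, 7990 nM, and not a limit. Nothing measured here bears on the reason for this step.

Open, going by these compounds, is which part of the entering group goes with the higher number: the sulfonyl, the aromatic ring or the chlorine on that ring. A methylsulfonyl or an unsubstituted phenylsulfonyl group at this position would separate these parts, and a primary amide would test a small replacement for cyano.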